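The source may hold more compounds than are shown below. What is called first, only, known or untested is meant among the compounds shown, and "the series" means these compounds.

Compound 3 `NC(=O)C1CCN(c2nc(-c3cccnc3)nc3c2CN(Cc2ccccc2)CC3)CC1` carries a pyridin-3-yl group on the shared core, and in an assay on A549 cells with Cystic fibrosis transmembrane conductance regulator variant F508del (Homo sapiens) as the target, read by fluorescence, with a stated time of 25 min (a lower number here means a smaller maximal response, a higher number a larger maximal response), compound 3 is recorded as "not active" (no number reported), so no number tells where it stands. Compound 4 `CN1CCN(CCCNc2nc(-c3cccnc3)nc3c2CN(Cc2ccccc2)CC3)CC1` differs from it in one place: (3-(4-methylpiperazin-1-yl)propyl)amino in place of 4-carbamoylpiperidin-1-yl on an aromatic carbon. Among the measured compounds shown here, one measured step bears on such a change. Compound 1 `NC(=O)C1CCN(c2nc(-c3ccccn3)nc3c2CN(Cc2ccccc2)CC3)CC1` gives 34.4% in this assay, while compound 2 `CN(C)CCN1CCN(c2nc(-c3ccccn3)nc3c2CN(Cc2ccccc2)CC3)CC1` gives 57%; the step of a number 22.6 percentage points higher from compound 1 to compound 2 (beyond the scatter) followed a similar exchange of the 4-carbamoylpiperidin-1-yl group for an amine-bearing side chain. A rise of comparable size is therefore expected for compound 4, although compound 3 starts from no recorded activity, so compound 4 may again yield no number. Compound 4 is expected to give about 25% in this assay, between 5% and 50%.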

Compound 4, largest response reached (Emax), in percent of the reference or control that the assay uses: "not active" (no number reported)
The entry for compound 4 holds no number, and the estimate cannot be compared.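

In this assay compound 3 is recorded as "not active" (no number reported) and compound 4 as "not active" (no number reported) so no step can be read between them. The compounds shown leave open whether this side-chain exchange alters the maximal response on a core bearing a pyridin-3-yl group. Nothing available accounts for this result.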